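Changing the Side Chain of Compound 2

The compounds below may be only part of what the source reports. "The series", "measured", "known", "first", "only" and "open" are said of these compounds alone.

Measured in a functional assay on CCRF-CEM cells (Homo sapiens); on this read-out higher numbers stand for lower toxicity in this test and lower numbers for higher toxicity in this test:
- Compound 1 `CNC(=O)Cn1c(=O)c(C)cn([C@@H]2O[C@H](CO[Si](C)(C)C(C)(C)C)[C@@]3(OS(=O)(=O)C=C3N)[C@H]2O[Si](C)(C)C(C)(C)C)c1=O`: >= 250000 nM (a limit of the assay)
- Compound 2 `Cc1cn([C@@H]2O[C@H](CO[Si](C)(C)C(C)(C)C)[C@@]3(OS(=O)(=O)C=C3N)[C@H]2O[Si](C)(C)C(C)(C)C)c(=O)n(C/C=C/CO)c1=O`: 4410 nM

Among the compounds with values here, compound 2 gives 4410 nM, the only exact number so far. Compound 1 gives >= 250000 nM, which is a limit and not a number.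

Compound 3 `Cc1cn([C@@H]2O[C@H](CO[Si](C)(C)C(C)(C)C)[C@@]3(OS(=O)(=O)C=C3N)[C@H]2O[Si](C)(C)C(C)(C)C)c(=O)n(CCCN(C)C)c1=O` has not yet been measured. It differs from compound 2 in one place: 2-(dimethylamino)ethyl in place of 3-hydroxyprop-1-en-1-yl on a saturated chain carbon bound to an aromatic nitrogen. In words, 2-(dimethylamino)ethyl stands in place of 3-hydroxyprop-1-en-1-yl on a saturated chain carbon bound to an aromatic nitrogen.

Within the data shown here, one measured step bears on this change, since it falls at the same place: an at least 56-fold lower number from compound 1 to compound 2 (1.75 log units; beyond the scatter). It shows that a swap here can move the number a great deal, but one step cannot fix the direction for a new group. A moderate move towards lower toxicity is expected, giving an expected step of a 3.4-fold higher number from compound 2 to compound 3 (0.53 log units; beyond the scatter). For compound 3 the estimated value in this assay is 15000 nM, with an expected range of 3000 nM to 100000 nM.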

Compound 3, half-maximal cytotoxic concentration: 10400 nM
Compound 3: the middle estimate sits 1.4-fold (0.16 log units) above what was measured; the range from low to high includes it.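

In this assay, 2-(dimethylamino)ethyl in place of 3-hydroxyprop-1-en-1-yl gives a 2.4-fold higher number from compound 2 to compound 3 (0.37 log units; beyond the scatter), so losing the double bond and the hydrogen-bond donor of the old chain costs only a modest part of the toxicity in this test. Against the methylcarbamoyl group, the new chain gives an at least 24-fold lower number from compound 1 to compound 3 (1.38 log units; beyond the scatter), so the large shift seen earlier is not tied to the 4-hydroxybut-2-en-1-yl chain alone, since a 3-(dimethylamino)propyl chain shows it too. The size of that shift is not exact, since compound 1 sits at a limit and not at a number: the limit of >= 250000 nM in this assay, at which 1 of the 3 values shown sits.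

Still open, going by these compounds, is whether the amine matters at all, or whether a plain butyl chain on the same nitrogen would read the same. A carboxylic acid at the chain end, or a longer chain carrying the dimethylamino group, would test how far this position stretches.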